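Sulfonamide nitrogen swaps on a shared thiourea core

The compounds below may be only part of what the source reports. "The series", "measured", "known", "first", "only" and "open" are said of these compounds alone.

In a functional assay on HepG2 cells (Homo sapiens) for antiproliferative activity, read by sulforhodamine B assay, with a stated time of 48 h (on this read-out lower numbers stand for stronger inhibition and higher numbers for weaker inhibition), compound 1 `N=C(N)NS(=O)(=O)c1ccc(N/C(S)=N\c2ccnc3cc(C(F)(F)F)ccc23)cc1` gives 33500 nM and compound 2 `Cc1noc(NS(=O)(=O)c2ccc(N/C(S)=N\c3ccnc4cc(C(F)(F)F)ccc34)cc2)c1C` gives 36800 nM, the upper of the two numbers shown, though the gap to compound 1 lies within the scatter. Among the compounds with values here, the single measured step, a 1.1-fold higher number from compound 1 to compound 2 (0.04 log units; within the scatter), also exchanged the group on the sulfonamide nitrogen without moving the number beyond the scatter. Compound 3 `Cc1cc(C)nc(NS(=O)(=O)c2ccc(N/C(S)=N\c3ccnc4cc(C(F)(F)F)ccc34)cc2)n1` carries the change (4,6-dimethylpyrimidin-2-yl in place of 3,4-dimethyl-1,2-oxazol-5-yl on a sulfonamide nitrogen). On that one precedent the expected step is a 1.1-fold lower number from compound 2 to compound 3 (0.02 log units; within the scatter), no shift beyond the scatter in either direction. Compound 3 is estimated at 35000 nM, within 15000 nM to 80000 nM.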

Compound 3, half-maximal inhibitory concentration: 72200 nM
Compound 3: the middle estimate sits 2.1-fold (0.31 log units) below what was measured; the range from low to high includes it.
By their numbers in this assay, from the lowest: compounds 1, 2 and 3 (each within the scatter of the next, the first and the last beyond it).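

With 4,6-dimethylpyrimidin-2-yl on the sulfonamide nitrogen, the data show a 2.0-fold higher number from compound 2 to compound 3 (0.29 log units; within the scatter). Within the data shown here, the same group, set against the group on compound 1, gives a 2.2-fold higher number from compound 1 to compound 3 (0.33 log units; beyond the scatter), the first step at this position to clear the scatter, with compound 2 within the scatter of both neighbours in the ranking. No measurement here bears on the reason for these steps.

Still open, as far as these compounds go, is whether an acetyl group or a simple alkyl chain on the sulfonamide nitrogen would move the number well away from this narrow band. From the compounds shown here alone, how far changes elsewhere on the shared core would shift it also remains open.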